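Adding a second chlorine to a benzylic chloride purine core

The source may report more compounds than this note shows. Statements on the series, on what has been measured and on what is new or still open speak of the compounds shown alone.

Two compounds of this series have been run in a functional assay on HOP-62 cells (Homo sapiens) for cytotoxicity, read by sulforhodamine B assay, with a stated time of 48 h; a lower number here means a stronger inhibitor of growth, a higher number a weaker inhibitor of growth. Compound 1 `ClCc1ccc(Cn2cnc3c(Cl)ncnc32)cc1` gives 6760 nM in this assay. Compound 2 `ClCc1cccc(Cn2cnc3ncnc(Cl)c32)c1` gives 3980 nM in this assay, which is the smaller of the two numbers reported so far, though the gap between compound 2 and compound 1 lies within the scatter of repeated measurements, so neither can be called the stronger growth inhibitor on this evidence.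

Compound 3 `ClCc1cccc(Cn2cnc3nc(Cl)nc(Cl)c32)c1` has not yet been measured. It differs from compound 2 in one place: chloro in place of hydrogen on an aromatic carbon. The second chloro group thus sits between two ring nitrogen atoms of the fused core, meta to the existing chloro group.

Among the compounds with values here, no measured pair in this set reproduces this change, so the expectation rests on the two values alone. Since compound 1 and compound 2 differ only within the scatter, a modest step from compound 2 to compound 3 of a 1.3-fold lower number from compound 2 to compound 3 (0.12 log units; within the scatter) toward a smaller number is expected, but not one clearly beyond the scatter. Compound 3 is therefore estimated to give 3000 nM in this assay, with a range from 1000 nM to 9000 nM.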

Compound 3, concentration for total growth inhibition: 3630 nM
For compound 3 the middle estimate is 1.2-fold (0.08 log units) below the measured one, within the range that was stated.
By their numbers in this assay, from the lowest: compounds 3, 2 and 1 (each within the scatter of the next).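

In this assay, putting a chloro group on the aromatic carbon between two ring nitrogen atoms gives a 1.1-fold lower number from compound 2 to compound 3 (0.04 log units; within the scatter) and so leaves the number within the scatter of the hydrogen-bearing parent. Compound 1 and compound 2 both carry hydrogen at this carbon, so they could say nothing about a substituent here; compound 3 shows that this position can hold a chloro group, meta to the existing chloro group, with no readable difference from hydrogen in this growth read-out. Nothing measured here accounts for the flat result, and no independent data on the compounds bear on it.

The compounds shown leave open whether a different group on this carbon, such as an amine, a methoxy group or a longer chain, would move the number clearly beyond the scatter, or whether any replacement here matters at all. They also leave open whether the same change from hydrogen to chloro on the core of compound 1, with its own arrangement of the chloromethyl benzyl group, would give a similarly small step.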